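Swapping the amide substituent from sec-butyl to thiazole

This account rests on a few compounds, and the source may have more. Where it says the series, first, only, none or still open, it means among the compounds named here.

Of the compounds shown here, three sharing one core have been measured in an assay on HEK293 cells for agonist activity at transient receptor potential cation channel subfamily M member 8 (Homo sapiens), read by fluorescence and calcium flux, with a stated time of 15 min; a lower number here means that less compound is needed, a higher number that more compound is needed for the effect. Compound 1 `CCN(Cc1cccs1)C(=O)COc1ccc(C)cc1` gives 8 nM. Compound 2 `Cc1ccc(OCC(=O)N(Cc2cccs2)c2ccccn2)cc1` gives 200 nM, and compound 3 `CCC(C)N(Cc1cccs1)C(=O)COc1ccc(C)cc1` gives 2000 nM. Compound 3 thus stands highest of the three: the step of a 10-fold higher number from compound 2 to compound 3 (1.00 log units; beyond the scatter) separates it from its nearest neighbour, and the step of a 250-fold higher number from compound 1 to compound 3 (2.40 log units; beyond the scatter) from the most potent one, so it needs the most compound of the set.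

Compound 4 `Cc1ccc(OCC(=O)N(Cc2cccs2)c2nccs2)cc1` is not yet measured. It differs from compound 3 by 1,3-thiazol-2-yl in place of sec-butyl on an amide-type nitrogen. The most relevant precedent is the step of a 10-fold higher number from compound 2 to compound 3 (1.00 log units; beyond the scatter), where an aromatic six-membered ring on the same nitrogen was replaced by sec-butyl and the number rose. The step of a 25-fold higher number from compound 1 to compound 2 (1.40 log units; beyond the scatter) also bears on it, showing that an aromatic ring on this nitrogen sits between ethyl and sec-butyl. Reversing toward an aromatic ring is therefore expected to lower the number, roughly by the step of an 8.0-fold lower number from compound 3 to compound 4 (0.90 log units; beyond the scatter). Compound 4 is estimated at 250 nM, within a range of 60 nM to 1000 nM.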

Compound 4, half-maximal effective concentration: 2240 nM
Compound 4: the middle estimate sits 9.0-fold (0.95 log units) below what was measured; the whole stated range lies below it.
By their numbers in this assay, from the lowest: compound 1; then compound 2; then compounds 3 and 4 (each within the scatter of the next).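

In this assay the swap from sec-butyl to 1,3-thiazol-2-yl on the amide-type nitrogen makes no readable difference (a 1.1-fold higher number from compound 3 to compound 4 (0.05 log units; within the scatter)), so an aromatic ring at this place does not by itself give a lower number than sec-butyl. Compound 2 and compound 4 both carry an aromatic ring here, yet they are clearly apart (an 11-fold higher number from compound 2 to compound 4 (1.05 log units; beyond the scatter)), which shows that the identity of the ring matters and not merely its presence. Ethyl still gives the lowest number of the four groups (a 280-fold higher number from compound 1 to compound 4 (2.45 log units; beyond the scatter)), and nothing available explains the gap between the two rings.

Still open, from the compounds shown here alone, is whether a phenyl or pyridin-3-yl ring on this nitrogen would fall nearer compound 2 or compound 4. Going by these compounds, it is also open whether methyl or n-propyl would stay close to compound 1.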